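Series notes: from compound 1 to compound 3

This account rests on a few compounds, and the source may have more. Where it says the series, first, only, none or still open, it means among the compounds named here.

Measured so far:
- compound 1 `Cc1ccc2c(c1)oc(=O)n2Cc1cn(-c2ccc(F)cc2)nn1` — 81.4%
- compound 2 `O=c1oc2ccccc2n1Cc1cn(-c2cccnc2)nn1` — "active" (no number reported)

In a functional assay on the whole organism (strain albino Wistar) for inhibition, with Rattus norvegicus as the target, read by paw edema, with stated times of 1 h and 3 h, at a dose of 0.05 mmol/kg by the oral route (a lower number here means less inhibition, a higher number more inhibition at the dose given (going by the name of the read-out)), compound 1 gives 81.4%. For the measured compounds named here, this is the only number the series has so far; compound 2 is reported in this assay only as "active" (no number reported), without a figure, so compound 1 stands alone and no step between measured compounds can be stated. Compound 1 therefore cannot be ranked against anything, only taken as the single reference point.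

Compound 3 `Cc1ccc2c(c1)oc(=O)n2Cc1cn(-c2ccccc2Cl)nn1` differs from compound 1 in one place: 2-chlorophenyl in place of 4-fluorophenyl on an aromatic nitrogen. Going by the values given here, both groups are halophenyl rings of the same size on the same aromatic nitrogen, and there is no measured pair to show how such a swap moves the read-out.

Among the compounds with values here, with only one number available, the expected step from compound 1 to compound 3 in this assay is a number 7.4 percentage points lower from compound 1 to compound 3 (within the scatter), that is, none beyond the usual scatter, with the range widened to allow for the absence of any guiding pair. Compound 3 is accordingly estimated at 74%, between 52% and 90%.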

Compound 3, a percentage reported as inhibition, in the whole organism at one dose (the size of the read-out at that dose, not a potency): 71.8%
The estimate for compound 3 lay 2.2 percentage points above the measured number; the range from low to high includes it.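

In this assay the series now has its first readable step: 2-chlorophenyl in place of 4-fluorophenyl on the aromatic nitrogen gives a number 9.6 percentage points lower from compound 1 to compound 3 (within the scatter), so the two compounds cannot be told apart at the dose given. This shows that, for this pair, the halogen and its place on the phenyl ring can both differ, as the two group names print, while the read-out stays within the scatter; the claim extends no further than compound 1 and compound 3. No measurement shown bears on why the two compounds read alike.

Because both the halogen and its place differ in this single swap, the step cannot assign anything to either alone, and 4-chlorophenyl or 2-fluorophenyl on the same nitrogen would be needed to separate them. The compounds shown also leave open whether the read-out holds with no halogen on the ring, or with an amine, a carboxylic acid or a longer chain in place of the phenyl ring, and the step involving the unnumbered entry cannot be read.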